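A few compounds are considered here, and "the series" means these few. Any claim that something is new, unique, unknown or untested is made for them only; others in the source may bear on it.

Of the compounds shown here, three have been measured in a functional assay on HeLa cells (Homo sapiens) for inhibition, read by CCK-8 assay, with a stated time of 48 h; a lower number here means a stronger inhibitor, a higher number a weaker inhibitor. Compound 1, `COc1ccc(Oc2ccc([N+](=O)[O-])cc2-c2ccsc2S(=O)(=O)N2CCN(C(=O)Nc3ccc([N+](=O)[O-])cc3)CC2)cc1OC`, reports only a limit of the assay: in this assay compound 1 gives > 50000 nM. Among the measured compounds shown here, compound 2, `COc1ccc(Oc2ccc(C(C)C)cc2-c2ccsc2S(=O)(=O)NCCNC(=O)Nc2cc(Cl)cc(Cl)c2)cc1OC`, is the one member with a number, and in this assay compound 2 gives 11600 nM. Compound 3, `O=C(NCCNS(=O)(=O)c1ccc(-c2ccccc2Oc2ccc([N+](=O)[O-])c([N+](=O)[O-])c2)s1)Nc1cc(C(F)(F)F)cc(C(F)(F)F)c1`, likewise sits at a limit of the assay, and in this assay compound 3 gives > 50000 nM. Compound 3 therefore stands where no number has been reached, a position it shares with one other member of the set, the relevant line being (the limit of > 50000 nM in this assay, at which 2 of the 3 values shown sit). For the measured compounds named here, no step between measured compounds that differ in one place is available, so the move to compound 4, `O=C(NCCNS(=O)(=O)c1ccc(-c2ccccc2O[C@H]2CC[C@@H](O)CC2)s1)Nc1cc(C(F)(F)F)cc(C(F)(F)F)c1`, rests on the structural change alone: 4-hydroxycyclohexyl in place of 3,4-dinitrophenyl on an oxygen on an aromatic ring. Nothing measured here shows what that exchange does to inhibition. The step from compound 3 to compound 4 is expected to be an at least 1.6-fold lower number from compound 3 to compound 4 (0.22 log units; that floor lies within the scatter) in this assay, which may amount to no more than the scatter and could leave compound 4 at a limit as well. Compound 4 is accordingly estimated at 30000 nM in this assay, within a range from 8000 nM to 100000 nM.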

Compound 4, half-maximal inhibitory concentration: 14100 nM
Estimate against measurement, compound 4: 2.1-fold (0.33 log units) above, within the range that was stated.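

Among the compounds shown here, on the oxygen on an aromatic ring, 4-hydroxycyclohexyl in place of 3,4-dinitrophenyl gives, in this assay, an at least 3.5-fold lower number from compound 3 to compound 4 (0.54 log units; beyond the scatter), the first comparison between compounds that differ in one place. It shows that this position can change the read-out by more than the scatter and that the aromatic 3,4-dinitrophenyl group is not needed for a measurable value, since compound 4 gives 14100 nM with a non-aromatic ring of carbon in that place. The size of the step is only a floor, because the value of compound 3 is a limit of the assay and not a number: the limit of > 50000 nM in this assay, at which 2 of the 4 values shown sit.

The exchange alters several things at once, replacing an aromatic ring with a non-aromatic one, removing both nitro groups and adding a hydroxyl with two defined stereocentres, and the compounds shown do not separate these parts. From the compounds shown here alone, it remains open how an unsubstituted phenyl, a cyclohexyl without the hydroxyl, a 4-aminocyclohexyl or the other stereoisomer of the 4-hydroxycyclohexyl group would read on that oxygen.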